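Benzylamine aryl replacement in a bis(trifluoromethyl)sulfonamide series

A few compounds are considered here, and "the series" means these few. Any claim that something is new, unique, unknown or untested is made for them only; others in the source may bear on it.

Measured so far:
compound 1 `O=S(=O)(NCCNCc1cccc2ccccc12)c1cc(C(F)(F)F)cc(C(F)(F)F)c1` gives 24000 nM
compound 2 `O=S(=O)(NCCCNCc1ccc(Cl)c(Cl)c1)c1cc(C(F)(F)F)cc(C(F)(F)F)c1` gives 5600 nM
compound 3 `O=S(=O)(NCCCNCc1ccc(Cl)c(C(F)(F)F)c1)c1cc(C(F)(F)F)cc(C(F)(F)F)c1` gives 10000 nM

Compound 3 holds the second highest of the three numbers in a functional assay on PANC-1 cells (Homo sapiens) for inhibition, read by MTT assay, with a stated time of 72 h; on this read-out lower numbers stand for stronger inhibition of growth and higher numbers for weaker inhibition of growth. Its nearest neighbour is compound 2, separated by a 1.8-fold higher number from compound 2 to compound 3 (0.25 log units; within the scatter). Among the measured compounds shown here, its furthest is compound 1, whose value in this assay is higher than that of compound 3 by a gap beyond the scatter; those two compounds differ in more than one place, so no single step is drawn between them.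

Compound 4 `COc1ccc(CNCCCNS(=O)(=O)c2cc(C(F)(F)F)cc(C(F)(F)F)c2)cc1` is the next compound. The change from compound 3 is 4-methoxyphenyl in place of 4-chloro-3-(trifluoromethyl)phenyl on a saturated chain carbon bound to an amine nitrogen. For the measured compounds named here, the only measured step, the swap between compound 2 and compound 3, concerns a substituent exchange within the same ring and stays within the scatter, so it does not bear directly on the loss of both ring substituents and the entry of a methoxy group. The values of compound 1 and compound 2 show that changes at this end of the chain can move the number well beyond the scatter in either direction, but nothing measured points to which.

On that basis, the number for compound 4 is expected to sit near that of compound 3 with a wide range, as an estimated 1.8-fold higher number from compound 3 to compound 4 (0.26 log units; within the scatter); compound 4 is estimated at 18000 nM, between 6000 nM and 55000 nM.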

Compound 4, concentration for 50% growth inhibition: 11000 nM
Compound 4: the middle estimate sits 1.6-fold (0.21 log units) above what was measured, and the stated range covers the measured number.
By their numbers in this assay, from the lowest: compounds 2, 3 and 4 (each within the scatter of the next); then compound 1.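

In this assay the exchange of 4-chloro-3-(trifluoromethyl)phenyl for 4-methoxyphenyl on a saturated chain carbon bound to an amine nitrogen gives a 1.1-fold higher number from compound 3 to compound 4 (0.04 log units; within the scatter) and the exchange of 3,4-dichlorophenyl for 4-methoxyphenyl at the same place gives a 2.0-fold higher number from compound 2 to compound 4 (0.29 log units; within the scatter) in this comparison. Where the earlier step swapped only one substituent on the ring, these steps replace the whole substituent pattern, including every halogen, and compound 2, compound 3 and compound 4 still cannot be separated in this assay, so among these three compounds the read-out does not distinguish the halogen-bearing rings from the methoxy-bearing ring. No supporting evidence bears on this result.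

The gap between compound 1 and the others remains unassigned, since compound 1 differs from each of them in more than one place, and its aryl group and its chain cannot be weighed separately. Going by these compounds, it also remains open whether a ring carrying a carboxylic acid or an amine at this position, or a longer chain between the two nitrogens, would give a number beyond the scatter of this cluster.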